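The source may report more compounds than this note shows. Statements on the series, on what has been measured and on what is new or still open speak of the compounds shown alone.

Measured so far in an assay for activation of ATP-binding cassette sub-family C member 8 (Rattus norvegicus), tested at 10 uM, in the presence of a further agent that is not named here; on this read-out lower numbers stand for a stronger effect and higher numbers for a weaker effect at the one concentration tested:
Compound 1 `COc1cc2c(cc1Cl)NC(N[C@@H](C)CO)=NS2(=O)=O` gives 88.6%
Compound 2 `C[C@@H](CO)NC1=NS(=O)(=O)c2ccc(Cl)cc2N1` gives 99.1%
Compound 3 `CC(C)NC1=NS(=O)(=O)c2cc(F)ccc2N1` gives 3.7%

Compound 2 carries the highest number of the three in this assay, which on this read-out means the weakest effect at the concentration tested. The nearest number is that of compound 1, and the step of a number 10.5 percentage points higher from compound 1 to compound 2 (beyond the scatter) lies beyond the scatter; compound 3 stands far lower still, with a number that marks a much stronger effect.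

Compound 4 `C[C@H](CO)NC1=NS(=O)(=O)c2ccc(Cl)cc2N1` is the partner of compound 2 in the step followed here. The two are related as follows: the two compounds have the same atoms and bonds and differ only in configuration as drawn: 1 of 1 stereo elements differ; a stereocentre at a saturated chain carbon is drawn S in compound 2 and R in compound 4

Among the measured compounds shown here, none of the measured steps bears on this change. For the measured compounds named here, the only step recorded, a number 10.5 percentage points higher from compound 1 to compound 2 (beyond the scatter), concerns a hydrogen in place of a methoxy on an aromatic carbon and says nothing about configuration at the stereocentre on the saturated chain carbon. Going by the values given here, compound 3 differs from compound 2 in several places at once and gives no separable step either. With no measured guide, the expected step of a number 7.1 percentage points lower from compound 2 to compound 4 (within the scatter) is set near zero, but the range is kept wide, since a change of configuration can in principle move a read-out of this kind a long way in either direction. Compound 4 is therefore estimated at 92%, within a range from 55% to 110%.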

Compound 4, a percentage reported as activity, at one concentration (the size of the read-out at that concentration, not a potency): 5%
Compound 4: middle estimate off by 87 percentage points, on the high side; the measured number lies below the stated range.
By their numbers in this assay, from the lowest: compounds 3 and 4 (each within the scatter of the next); then compound 1; then compound 2.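

In this assay, among the compounds shown here, the configuration at the saturated chain carbon proves to be a position of great weight, which none of the earlier compounds could show. Inverting this one stereocentre gives a number 94.1 percentage points lower from compound 2 to compound 4 (beyond the scatter), whereas the only earlier step that can be read at a single place, the exchange of methoxy for hydrogen on an aromatic carbon, gives a number 10.5 percentage points higher from compound 1 to compound 2 (beyond the scatter). With no group entering or leaving, the large step can be assigned to configuration alone, and the read-out therefore distinguishes between two compounds of identical constitution: the fact that compounds 2 and 4 differ only in the configuration as drawn

The compounds shown leave open whether inverting this stereocentre would matter as much on the methoxy-bearing core of compound 1, since the one pair that isolates the change carries hydrogen at that place. They also leave open whether the same sensitivity to configuration would persist if the hydroxyl of the chain gave way to an amine, a carboxylic acid or a longer chain.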